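Swapping Fluoro for Chloro on a Rearranged Core

The source may hold more compounds than are shown below. What is called first, only, known or untested is meant among the compounds shown, and "the series" means these compounds.

Compound 1 `COc1ccc(N/C=C\C(=O)c2cn(-c3ccccc3)nc2-c2ccc(F)cc2)cc1` and compound 2 `COc1ccc(N/C=C\C(=O)c2cn(-c3ccccc3)nc2-c2ccc(Cl)cc2)cc1` share one core and differ in a single place: chloro in place of fluoro on an aromatic carbon. In an ADME assay on HaCaT cells (Homo sapiens) for antiproliferative activity, read by MTT assay, with a stated time of 48 h (a lower number here means a stronger inhibitor, a higher number a weaker inhibitor), compound 1 gives 19600 nM, and compound 2 gives 30800 nM. The step is a 1.6-fold higher number from compound 1 to compound 2 (0.20 log units; within the scatter), so the two numbers cannot be told apart with confidence.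

Compound 3 `COc1ccc(-c2nn(-c3ccccc3)cc2C(=O)/C=C\Nc2ccc(F)cc2)cc1` is built from the same atoms as compound 1, joined differently, and the difference between the two cores is not broken down here. In this assay compound 3 gives 8910 nM, the lowest of the three numbers, beyond the scatter from both compound 1 and compound 2.

Compound 4 `COc1ccc(-c2nn(-c3ccccc3)cc2C(=O)/C=C\Nc2ccc(Cl)cc2)cc1` is the one not yet measured. It differs from compound 3 in one place: chloro in place of fluoro on an aromatic carbon. The place is the same in words as the place of the change from compound 1 to compound 2; cut one bond further out, it reads (4-fluorophenyl)amino to (4-chlorophenyl)amino, so the ring carrying the halogen is the one attached through the amino group.

Because the measured step of a 1.6-fold higher number from compound 1 to compound 2 (0.20 log units; within the scatter) stayed within the scatter, the same change made on compound 3 is expected to give a step of about a 1.5-fold higher number from compound 3 to compound 4 (0.16 log units; within the scatter) in this assay, also within the scatter. For compound 4 the estimated value in this assay is 13000 nM, with a likely range from 6000 nM to 30000 nM.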

Compound 4, half-maximal inhibitory concentration: 20900 nM
Beside the measured number, compound 4's estimate is 1.6-fold (0.21 log units) below it, and the stated range covers the measured number.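

In this assay the swap of chloro for fluoro on the core of compound 3 gives a 2.3-fold higher number from compound 3 to compound 4 (0.37 log units; beyond the scatter) and so, on this core, the step lies beyond the usual scatter of repeated measurements, though only modestly. Set beside the same swap on the core of compound 1, the two steps cannot be told apart: the same change on two cores in this assay, a 1.6-fold higher number (0.20 log units; within the scatter) from compound 1 to compound 2 and a 2.3-fold higher number (0.37 log units; beyond the scatter) from compound 3 to compound 4, 1.5-fold (0.17 log units) apart, within the scatter of two such steps. This fits the idea that the change carries from one core to the other without a clear difference in size, but it rests on a single pair of compounds per core and does not show that the step would be the same on any further core, or why it has the size it has.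

The compounds shown hold only fluoro and chloro at this place, so it stays open whether a bromo, a methyl or a carboxylic acid there would follow the same steps on both cores. The methoxy group also stands unchanged throughout, which leaves open how a hydroxy group or an amine in its stead would behave alongside either halogen.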